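The source may report more compounds than this note shows. Statements on the series, on what has been measured and on what is new or still open speak of the compounds shown alone.

In an assay on HEK293 cells for inhibition of Voltage-dependent T-type calcium channel subunit alpha-1G (Homo sapiens), read by fluorescence, tested at 10 uM (on this read-out lower numbers stand for less inhibition and higher numbers for more inhibition at the one concentration tested (going by the name of the read-out)), three compounds have been measured:

Compound 1, `CCCc1nc(-c2ccccc2)c(CNCCN2CCN(c3cccc(C)c3)CC2)o1`: 43.1%
Compound 2, `CCCc1nc(-c2ccccc2)c(CNCCCN2CCN(c3ccc(C)cc3)CC2)o1`: 53.9%
Compound 3, `CCCc1nc(-c2ccccc2)c(CNCCCN2CCN(c3ccccc3F)CC2)o1`: 54.4%

Compound 1 stands lowest of the three; compound 2 is its nearest neighbour, and compound 3 its furthest, both of them beyond the scatter above compound 1. Going by the values given here, no single-place step links compound 1 to either of them.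

The next compound, compound 4, is `CCCc1nc(-c2ccccc2)c(CNCCN2CCN(c3cccc(Cl)c3)CC2)o1`. It differs from compound 1 by chloro in place of methyl on an aromatic carbon.

Among the compounds with values here, only one measured step bears on this change: the exchange of one aryl group for another on the same amine nitrogen, a number 0.5 percentage points higher from compound 2 to compound 3 (within the scatter). That swap left the read-out essentially unchanged. Within the data shown here, the change from compound 1 to compound 4 is smaller still, a single substituent on the aromatic ring, and nothing among the measured compounds points to a shift in either direction. Compound 4 is therefore expected to sit near compound 1, with an estimated step of a number 1.9 percentage points higher from compound 1 to compound 4 (within the scatter). The estimate for compound 4 in this assay is 45%, within a range from 30% to 60%.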

Compound 4, a percentage reported as inhibition, at one concentration (the size of the read-out at that concentration, not a potency): 51.2%
For compound 4 the middle estimate is 6.2 percentage points below the measured one, within the range that was stated.
By their numbers in this assay, from the lowest: compounds 1, 4, 2 and 3 (each within the scatter of the next, the first and the last beyond it).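

In this assay, going by these compounds alone, this pair gives the first direct look at one substituent on an aromatic carbon, meta to a large group, with all else held constant: the step with chloro in place of methyl is a number 8.1 percentage points higher from compound 1 to compound 4 (within the scatter). Within this read-out, then, 3-chlorophenyl and 3-methylphenyl cannot be told apart on this shared core, so either group is compatible with a similar reading at this place. No available evidence accounts for the size of this step.

From the compounds shown here alone, how a bromo, methoxy or trifluoromethyl group would read at the same place remains open, as does what an amine or a carboxylic acid there would give. Also open, going by these compounds, is whether chloro and methyl would again read alike on the longer chain carried by compound 2 and compound 3.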